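Dropping one methoxy from a coumarin aromatase inhibitor

The compounds below may be only part of what the source reports. "The series", "measured", "known", "first", "only" and "open" are said of these compounds alone.

Compound 1 `COc1ccc(COc2ccc3c(Cn4ccnc4)cc(=O)oc3c2)cc1OC` was tested in an assay for inhibition of Aromatase (Homo sapiens), read by scintillation counting, using microsomes, with a stated time of 5 min (on this read-out higher numbers stand for weaker inhibition and lower numbers for stronger inhibition), where compound 1 gives 445 nM. Its closest companion, compound 2 `CC(C)Oc1ccc(COc2ccc3c(Cn4ccnc4)cc(=O)oc3c2)cc1`, gives 584 nM in this assay, and the two numbers lie within the scatter of each other, so neither stands apart. Compound 3 `COc1cccc(COc2ccc3c(Cn4ccnc4)cc(=O)oc3c2)c1` has not yet been measured. Relative to compound 1 it carries hydrogen in place of methoxy on an aromatic carbon, hydrogen in place of methoxy on an aromatic carbon. Going by the values given here, no measured pair shows this change, so the step from compound 1 to compound 3 is expected to be small, a 1.2-fold higher number from compound 1 to compound 3 (0.07 log units; within the scatter), with no clear direction beyond the scatter. For compound 3 the estimate is 520 nM, within 220 nM to 1300 nM.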

Compound 3, half-maximal inhibitory concentration: 549 nM
Compound 3: middle estimate off by 1.1-fold (0.02 log units), on the low side, within the range that was stated.
By their numbers in this assay, from the lowest: compounds 1, 3 and 2 (each within the scatter of the next).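

In this assay, going by these compounds alone, hydrogen in place of the methoxy that stands para to a large group and ortho to a methoxy group gives a 1.2-fold higher number from compound 1 to compound 3 (0.09 log units; within the scatter) as the first single-place step in this set. Within the data shown here, this position therefore tolerates the loss of that methoxy, and the remaining methoxy alone gives a number within the scatter of the one from compound 1. No measurement bearing on the reason for this is available. From the compounds shown here alone, whether an amine, a carboxylic acid or a longer chain at this position would give a step beyond the scatter remains open.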